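This account rests on a few compounds, and the source may have more. Where it says the series, first, only, none or still open, it means among the compounds named here.

Of the compounds shown here, three built on one shared core have been measured in a functional assay on HeLa cells (Homo sapiens) for antiproliferative activity, read by CCK-8 assay, with a stated time of 72 h; on this read-out lower numbers stand for stronger inhibition and higher numbers for weaker inhibition. Compound 1 (`COc1ccc(-c2cncnc2-c2cc(OC)c(OC)c(OC)c2)cc1F`) gives 500 nM, compound 2 (`COc1cc(-c2ncncc2-c2ccc(SC)cc2)cc(OC)c1OC`) gives 220 nM, and compound 3 (`COc1cc(-c2ncncc2-c2ccc(Br)cc2)cc(OC)c1OC`) gives 500 nM. Compound 3 therefore stands level with compound 1, and together they hold the highest of the three numbers. The next structure, compound 4 (`COc1cc(-c2ncncc2-c2ccc(B(O)O)cc2)cc(OC)c1OC`), differs from compound 3 by one change: a group of 3 heavy atoms (1 boron, 2 oxygen; no ring) in place of one bromine atom, on an aromatic carbon, para to a large group. Within the data shown here, two measured steps bear on this place. Bromo in place of methylsulfanyl gave a 2.3-fold higher number from compound 2 to compound 3 (0.36 log units; beyond the scatter), and 4-bromophenyl in place of 3-fluoro-4-methoxyphenyl gave no change at the digits printed from compound 1 to compound 3 (within the scatter). Changes here have thus moved the number modestly or not beyond the scatter. Among the measured compounds shown here, no measured compound carries the entering group, so the direction remains open, and no large step is expected in this assay. Compound 4 is estimated at 400 nM, with an expected range from 100 nM to 1500 nM. The expected change is a 1.3-fold lower number from compound 3 to compound 4 (0.10 log units; within the scatter).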

Compound 4, half-maximal inhibitory concentration: 4000 nM
For compound 4 the middle estimate is 10-fold (1.00 log units) below the measured one; measured number outside the range, above it.
By their numbers in this assay, from the lowest: compound 2; then compounds 1 and 3 (each within the scatter of the next); then compound 4.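

In this assay, among these compounds, the aromatic carbon para to a large group proves more sensitive than the earlier compounds suggested, since the group of 3 heavy atoms (1 boron, 2 oxygen) in place of bromo gives a clear loss (an 8.0-fold higher number from compound 3 to compound 4 (0.90 log units; beyond the scatter)). The same group in place of methylsulfanyl gives the largest step of the set (an 18-fold higher number from compound 2 to compound 4 (1.26 log units; beyond the scatter)), and in place of the whole 3-fluoro-4-methoxyphenyl it gives a further loss (an 8.0-fold higher number from compound 1 to compound 4 (0.90 log units; beyond the scatter)). Nothing available accounts for these losses.

The compounds shown leave open whether the loss goes with the hydrogen-bond donors and acceptors counted for the entering group, which bromo lacks. A hydroxyl, an amine or a carboxylic acid at this place could test that, and a methoxy would carry no donor for comparison.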